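Swapping Dimethoxyphenyl for Iodophenyl on Two Amide Cores

A few compounds are considered here, and "the series" means these few. Any claim that something is new, unique, unknown or untested is made for them only; others in the source may bear on it.

Compound 1 `COc1ccc(C(=O)Nc2ccc(N(C)S(C)(=O)=O)c(OCc3cc(C(F)(F)F)ccc3C)c2)cc1OC` and compound 2 `Cc1ccc(C(F)(F)F)cc1COc1cc(NC(=O)c2ccc(I)cc2)ccc1N(C)S(C)(=O)=O` share one core and differ only at the amide end: 4-iodophenyl in place of 3,4-dimethoxyphenyl on a carbonyl carbon. In a functional assay on SK-BR-3 cells (Homo sapiens) for antiproliferative activity, read by MTT assay, with a stated time of 48 h (on this read-out lower numbers stand for stronger inhibition and higher numbers for weaker inhibition), compound 1 gives 16900 nM, and compound 2 gives 3500 nM. This single change therefore produced a 4.8-fold lower number from compound 1 to compound 2 (0.68 log units; beyond the scatter).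

Compound 3 `COc1ccc(OC)c(COc2cc(NC(=O)c3ccc(OC)c(OC)c3)ccc2N(C)S(=O)(=O)C(F)(F)F)c1` is built on a different core, and the difference between the two cores is not broken down here. In this assay, within the data shown here, compound 3 gives 550 nM, the lowest of the three numbers measured so far. Compound 4 `COc1ccc(OC)c(COc2cc(NC(=O)c3ccc(I)cc3)ccc2N(C)S(=O)(=O)C(F)(F)F)c1` stands to compound 3 exactly as compound 2 stands to compound 1: 4-iodophenyl in place of 3,4-dimethoxyphenyl on a carbonyl carbon. The place of the change is described in the same words on both cores, so this is the same change made a second time.

Among the measured compounds shown here, only one earlier instance of the change exists, and it sits on a different core, so any expectation rests on that single step alone. The step from compound 3 to compound 4 is expected to be a 3.4-fold lower number from compound 3 to compound 4 (0.54 log units; beyond the scatter), somewhat smaller than the earlier one because the earlier step of a 4.8-fold lower number from compound 1 to compound 2 (0.68 log units; beyond the scatter) was measured on a core that is not the core of compound 3, and a change need not carry over in full. Compound 4 is therefore expected to give about 160 nM in this assay, with a plausible range from 50 nM to 500 nM.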

Compound 4, half-maximal inhibitory concentration: 510 nM
Beside the measured number, compound 4's estimate is 3.2-fold (0.50 log units) below it; the whole stated range lies below it.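

On the other core, the same swap of 3,4-dimethoxyphenyl for 4-iodophenyl gives, in this assay, a 1.1-fold lower number from compound 3 to compound 4 (0.03 log units; within the scatter), so the clear drop seen on the core of compound 1 does not reappear. The outcome of this change therefore depends on the core that carries it, and the two steps really do differ: the same change on two cores in this assay, a 4.8-fold lower number (0.68 log units; beyond the scatter) from compound 1 to compound 2 and a 1.1-fold lower number (0.03 log units; within the scatter) from compound 3 to compound 4, 4.5-fold (0.65 log units) apart, beyond the scatter of two such steps. This does not show which part of the core is responsible, since the two cores are not broken down into single changes, and two instances cannot predict how the swap would behave on a third core.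

The swap also removes both methoxy groups and adds the iodine in a single move, so the compounds shown cannot separate what losing the former does from what gaining the latter does on either core. Going by these compounds, it remains open whether a plain phenyl, or a phenyl ring carrying an amine or a carboxylic acid, at the amide end would follow the pattern of the core of compound 1 or that of the core of compound 3.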